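This account rests on a few compounds, and the source may have more. Where it says the series, first, only, none or still open, it means among the compounds named here.

In a functional assay on MCF7 cells (Homo sapiens) for inhibition, read by MTT assay, with a stated time of 72 h (on this read-out higher numbers stand for weaker inhibition and lower numbers for stronger inhibition), three compounds built on one shared core have been measured. Compound 1 `N#Cc1c(Nc2ccccc2F)nc(SCc2cn(Cc3ccccc3Cl)nn2)nc1-c1ccccc1` gives 8060 nM. Compound 2 `Cc1ccccc1Nc1nc(SCc2cn(Cc3ccccc3Cl)nn2)nc(-c2ccccc2)c1C#N` carries a methyl where compound 1 carries a fluoro, and compound 2 gives 7950 nM; the step of a 1.0-fold lower number from compound 1 to compound 2 (0.01 log units; within the scatter) lies within the scatter. Compound 3 `Cc1ccccc1Nc1nc(SCc2cn(Cc3ccc(Cl)cc3)nn2)nc(-c2ccccc2)c1C#N` has 4-chlorophenyl in place of 2-chlorophenyl on a saturated chain carbon bound to an aromatic nitrogen. For compound 3 this assay reports only a limit, > 64000 nM, which is the limit of > 64000 nM in this assay, at which 1 of the 3 values shown sits. The step of an at least 8.0-fold higher number from compound 2 to compound 3 (0.90 log units; beyond the scatter) is beyond the scatter, so compound 3 stands at the weak end of the three, with no number of its own.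

Compound 4 `N#Cc1c(Nc2ccccc2F)nc(SCc2cn(Cc3ccc(Cl)cc3)nn2)nc1-c1ccccc1` has not yet been measured. It differs from compound 3 by fluoro in place of methyl on an aromatic carbon. This is the same exchange as between compound 1 and compound 2, read in the opposite direction, and that step, a 1.0-fold lower number from compound 1 to compound 2 (0.01 log units; within the scatter), was within the scatter. Within the data shown here, the only change that moved the read-out beyond the scatter was the swap of the chlorophenyl group, which compound 4 keeps from compound 3. The expected step that the limit leaves unreadable from compound 3 to compound 4 is therefore none beyond the scatter. Compound 4 is expected to give about 80000 nM, estimated between 30000 nM and 250000 nM, and most likely again only a limit.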

Compound 4, half-maximal inhibitory concentration: > 64000 nM
Compound 4 ended at the assay's limit; the forecaster's own chance of this, stated with the estimate: 70%; the middle value does not contradict the limit.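

In this assay, among these compounds, the swap of 2-chlorophenyl for 4-chlorophenyl had been seen only with (2-methylphenyl)amino on the shared core, and it now appears with (2-fluorophenyl)amino as well, as an at least 7.9-fold higher number from compound 1 to compound 4 (0.89 log units; beyond the scatter). The loss of inhibition therefore no longer rests on a single pair of compounds, and the two pairs point the same way: the same change on two cores in this assay, an at least 8.0-fold higher number (0.90 log units; beyond the scatter) from compound 2 to compound 3 and an at least 7.9-fold higher number (0.89 log units; beyond the scatter) from compound 1 to compound 4; the limit leaves it open whether they differ

The exchange of methyl for fluoro, which stayed within the scatter alongside 2-chlorophenyl, gains no size alongside 4-chlorophenyl, since compound 3 and compound 4 both give only a limit and the step between them cannot be read: the limit of > 64000 nM in this assay, at which 2 of the 4 values shown sit.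

The compounds shown leave open how far past the limit compound 3 and compound 4 lie, and so whether methyl and fluoro differ at all once 4-chlorophenyl is in place. They also leave open how the read-out would respond to a methoxy group or an amine on that aromatic carbon, or to 3-chlorophenyl in place of the two chlorophenyl groups tried so far.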